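Replacing thiophen-3-yl with 4-chlorophenyl in a T47D series

The compounds below may be only part of what the source reports. "The series", "measured", "known", "first", "only" and "open" are said of these compounds alone.

Measured compounds:
compound 1 `c1ccc2c(-c3cn4ccnc4c(-c4ccc5ncn(C6CCCCC6)c5c4)n3)cccc2c1` gives 41.3% in a functional assay on T47D cells (Homo sapiens) for inhibition, read by sulforhodamine B assay, with a stated time of 48 h, tested at 10 uM; on this read-out lower numbers stand for less inhibition and higher numbers for more inhibition at the one concentration tested (going by the name of the read-out);
compound 2 `c1cn2cc(-c3ccsc3)nc(-c3ccc4ncn(C5CCCCC5)c4c3)c2n1` gives 63.7% in this assay.

Going by the values given here, compound 2 stands highest of the two numbers so far in this assay, with compound 1 nearest and lower by the step of a number 22.4 percentage points higher from compound 1 to compound 2 (beyond the scatter). Compound 3 `Clc1ccc(-c2cn3ccnc3c(-c3ccc4ncn(C5CCCCC5)c4c3)n2)cc1` differs from compound 2 by 4-chlorophenyl in place of thiophen-3-yl on an aromatic carbon. Among the compounds with values here, the one step that bears on this change is the one at the same aromatic carbon, a number 22.4 percentage points higher from compound 1 to compound 2 (beyond the scatter), which shows that swapping the aryl group there shifts inhibition beyond the scatter. Within the data shown here, no measured step involves 4-chlorophenyl itself, so the direction for compound 3 is uncertain. The author expects compound 3 to land between the two measured values, with a step of a number 8.7 percentage points lower from compound 2 to compound 3 (within the scatter) that is expected to be modest and downward. Compound 3 is therefore estimated at 55%, with a range from 35% to 75%.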

Compound 3, a percentage reported as inhibition, at one concentration (the size of the read-out at that concentration, not a potency): 27.6%
Estimate against measurement, compound 3: 27.4 percentage points above, outside the stated range (below it).
By their numbers in this assay, from the lowest: compound 3; then compound 1; then compound 2.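

In this assay the group at this aromatic carbon moves the read-out downward as well as upward: 4-chlorophenyl in place of thiophen-3-yl gives a number 36.1 percentage points lower from compound 2 to compound 3 (beyond the scatter) and in place of naphthalen-1-yl gives a number 13.7 percentage points lower from compound 1 to compound 3 (beyond the scatter) and so ranks below both. Among these three compounds, the six-membered aromatic ring of carbon only with its chlorine reads lowest, while thiophen-3-yl reads highest and naphthalen-1-yl falls between them. No measurement at hand accounts for these differences. The compounds shown leave open whether the fall with 4-chlorophenyl belongs to the chlorine or to the ring that carries it, which plain phenyl or 4-methoxyphenyl at the same carbon could help separate. They also leave open how thiophen-2-yl or pyridin-3-yl would compare with thiophen-3-yl there.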